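Notes on the benzyl ether variation

The compounds below may be only part of what the source reports. "The series", "measured", "known", "first", "only" and "open" are said of these compounds alone.

The series shares one core and differs only in the group carried on a saturated chain carbon bound to an oxygen on an aromatic ring. In a functional assay on Vas deferens for antagonist activity at Alpha-1A adrenergic receptor (Rattus norvegicus) (a higher number here means a more potent compound, by a factor of ten per unit of this negative logarithm, a lower number a less potent compound), compound 1 `COc1cccc(OC)c1OCCNCCOc1ccccc1OCc1ccccc1[N+](=O)[O-]` gives 8.2. Compound 2 `COc1cccc(OC)c1OCCNCCOc1ccccc1OCc1cccc([N+](=O)[O-])c1` gives 8.85 in this assay, and compound 3 `COc1ccc(COc2ccccc2OCCNCCOc2c(OC)cccc2OC)cc1` gives 8.54. Among these three numbers compound 3 stands second highest: a number 0.31 log units lower from compound 2 to compound 3 (beyond the scatter) and a number 0.34 log units higher from compound 1 to compound 3 (beyond the scatter), so it lies between the other two. The step of a number 0.65 log units higher from compound 1 to compound 2 (beyond the scatter) is the largest seen so far.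

Compound 4 `CCOc1ccc(COc2ccccc2OCCNCCOc2c(OC)cccc2OC)cc1` differs from compound 3 by methyl in place of hydrogen on a saturated chain carbon bound to an oxygen on an aromatic ring. Among the compounds with values here, none of the measured steps touches this kind of change: each of them swaps one whole aryl group for another, whereas here a single carbon is added to the methoxy, giving 4-ethoxyphenyl in place of 4-methoxyphenyl. The measured steps are all modest in size, and nothing among them speaks for a move in either direction. The expectation is therefore no change at the digits printed from compound 3 to compound 4 (within the scatter), a step not beyond the scatter. In this assay compound 4 is thus estimated at 8.54, with a range from 8 to 9.05.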

Compound 4, negative logarithm of the antagonist equilibrium constant: 8.5
Estimate against measurement, compound 4: 0.04 log units above; measured number inside the range.
By their numbers in this assay, from the lowest: compounds 1, 4 and 3 (each within the scatter of the next, the first and the last beyond it); then compound 2.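

In this assay, within the data shown here, the first change that extends the substituent rather than swapping the whole aryl group leaves the number within the scatter (a number 0.04 log units lower from compound 3 to compound 4 (within the scatter)), so at this position 4-ethoxyphenyl reads the same as 4-methoxyphenyl. Against the two nitro compounds the picture is only partly the same: 3-nitrophenyl remains apart from 4-ethoxyphenyl (a number 0.35 log units lower from compound 2 to compound 4 (beyond the scatter)), while the gap to 2-nitrophenyl now falls within the scatter (a number 0.30 log units higher from compound 1 to compound 4 (within the scatter)), though the corresponding step to compound 3 lay just beyond it. No accompanying measurement bears on why the added methyl leaves the number where it is.

On these data alone, a single step of this kind gives no trend with chain length, so it remains open whether a longer chain such as 4-butoxyphenyl would stay level with compound 3 and compound 4 or move away from them. As far as these compounds go, it is equally open whether a different group at the same place, such as an amine in 4-aminophenyl or a carboxylic acid in 4-carboxyphenyl, would come closer to compound 2.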